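Moving the fluorine from the 3- to the 2-position of the phenoxy ring

The source may report more compounds than this note shows. Statements on the series, on what has been measured and on what is new or still open speak of the compounds shown alone.

Measured so far:
compound 1 `O=C(Nc1cccc(C(=O)O)c1)N[C@H]1CC[C@H](Oc2ccc(F)cc2)CC1` — > 20000 nM
compound 2 `O=C(Nc1ccc(Br)cc1)N[C@H]1CC[C@H](Oc2ccc(F)cc2)CC1` — > 20000 nM
compound 3 `O=C(Nc1cccc(C(F)(F)F)c1)N[C@H]1CC[C@H](Oc2cccc(F)c2)CC1` — 2400 nM

Of the compounds shown here, three sharing one core have been tested in a functional assay on CRL2813 cells (Homo sapiens) for cytotoxicity, read by sulforhodamine B assay, with a stated time of 5 days; a lower number here means a stronger inhibitor, a higher number a weaker inhibitor. Compound 1 reaches only the limit of this assay, > 20000 nM. Compound 2 likewise gives only a limit, > 20000 nM. Among the compounds with values here, compound 3 is the one member of the set with a number, 2400 nM, and it therefore stands alone as the single readable value; the other two sit at the limit of > 20000 nM in this assay, at which 2 of the 3 values shown sit.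

Within the data shown here, the one measured step, a step that the two limits leave unreadable from compound 1 to compound 2, changes the group on the amide-type nitrogen. Both of its ends are limits, so its size cannot be read. It does not touch the place altered in compound 4 `O=C(Nc1cccc(C(F)(F)F)c1)N[C@H]1CC[C@H](Oc2ccccc2F)CC1`, which differs from compound 3 by 2-fluorophenyl in place of 3-fluorophenyl on an oxygen on a saturated carbon.

Among the measured compounds shown here, no measured step bears on this change, so the expectation rests on compound 3 alone: the step of no change at the digits printed from compound 3 to compound 4 (within the scatter) is expected to lie within the scatter. Compound 4 is estimated at 2400 nM, between 800 nM and 8000 nM.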

Compound 4, half-maximal inhibitory concentration: 2450 nM
The estimate for compound 4 lay 1.0-fold (0.01 log units) below the measured number; low and high end bracket the measured number.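

In this assay, the swap of 3-fluorophenyl for 2-fluorophenyl on the oxygen is a 1.0-fold higher number from compound 3 to compound 4 (0.01 log units; within the scatter), so the two placements of the fluorine on this ring cannot be told apart here. Within the data shown here, this is the first step that can be read as a size, since the step between the two compounds that reach only a limit of the assay cannot be read. Nothing shown offers an explanation for this result.

The compounds shown leave open whether the fluorine itself matters, as a plain phenyl, or a ring carrying a chlorine or a methoxy group instead, would be needed to tell. Also open, on these data alone, is whether this swap would read the same with something other than the 3-trifluoromethylphenyl group on the amide-type nitrogen, such as a phenyl ring carrying an amine.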